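Dithiocarbamate triazoles: a dichlorobenzyl variant weighed against three

The source may hold more compounds than are shown below. What is called first, only, known or untested is meant among the compounds shown, and "the series" means these compounds.

Compound 1 `COc1ccc(-n2cc(CSC(=S)N3CCN(C(=O)OC(C)(C)C)CC3)nn2)cc1`: 93100 nM
Compound 2 `Fc1ccc(Cn2cc(CSC(=S)N3CCNCC3)nn2)cc1`: 49900 nM
Compound 3 `CC(C)(C)OC(=O)N1CCN(C(=S)SCc2cn(Cc3cc(=O)oc4cc(O)ccc34)nn2)CC1`: 10400 nM

Of the compounds shown here, three sharing a dithiocarbamate-triazole core have been measured in a functional assay on MCF7 cells (Homo sapiens) for inhibition, read by MTT assay, with a stated time of 72 h; on this read-out higher numbers stand for weaker inhibition and lower numbers for stronger inhibition. Compound 1 gives 93100 nM, the highest of the three numbers. Compound 2 gives 49900 nM, which lies within the usual scatter of compound 1, so the two cannot be placed in order. Compound 3 gives 10400 nM, a number beyond the scatter below compound 1. For the measured compounds named here, no single-point steps between measured compounds are available, so the influence of any one change is not known from these data.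

Compound 4 `CC(C)(C)OC(=O)N1CCN(C(=S)SCc2cn(Cc3ccc(Cl)c(Cl)c3)nn2)CC1` has not yet been measured. It differs from compound 1 by 3,4-dichlorobenzyl in place of 4-methoxyphenyl on an aromatic nitrogen. Going by the values given here, the only hint comes from compounds 2 and 3, whose benzyl-type groups on that nitrogen accompany lower numbers than compound 1 in this assay, though each also carries other differences. The step from compound 1 to compound 4 is therefore expected to be modest and downward, about a 2.7-fold lower number from compound 1 to compound 4 (0.42 log units; beyond the scatter). Compound 4 is estimated at 35000 nM, with a range from 12000 nM to 100000 nM.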

Compound 4, half-maximal inhibitory concentration: 19100 nM
Beside the measured number, compound 4's estimate is 1.8-fold (0.26 log units) above it; the measured number falls inside the stated range.
By their numbers in this assay, from the lowest: compounds 3 and 4 (each within the scatter of the next); then compounds 2 and 1 (each within the scatter of the next).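

In this assay, putting 3,4-dichlorobenzyl in place of 4-methoxyphenyl on the aromatic nitrogen, with the rest of the molecule unchanged, gives a 4.9-fold lower number from compound 1 to compound 4 (0.69 log units; beyond the scatter). For the compounds shown here, this is the first step that differs in one place only, so it shows directly that the group on this nitrogen can shift the number by more than the usual scatter, which compounds 2 and 3 could not show because they differ in other places too. Nothing available bears on what lies behind this step.

The whole group is exchanged at once, so the compounds shown do not separate the part played by the chlorines from that of the benzyl form. As far as these compounds go, an unsubstituted benzyl or a 3,4-dichlorophenyl on this nitrogen would bear on that question, and how an amine or a carboxylic acid there would read remains open.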